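Removing the chloro from compound 1's urea-bearing aryl ring

A few compounds are considered here, and "the series" means these few. Any claim that something is new, unique, unknown or untested is made for them only; others in the source may bear on it.

Compound 1 `COc1cc(Cl)cc(-c2nn(-c3cccc(NC(=O)Nc4ccc(Cl)c(C(F)(F)F)c4)c3)cc2-c2ccncc2)c1` was tested in a functional assay on NCI-H226 cells (Homo sapiens) for inhibition, read by sulforhodamine B assay, with a stated time of 48 h, tested at 100 uM (on this read-out lower numbers stand for a stronger effect and higher numbers for a weaker effect at the one concentration tested), where compound 1 gives -29%. Among the three measured numbers it stands second highest: compound 2 `COc1cc(Cl)cc(-c2nn(-c3cccc(NC(=O)Nc4cc(C(F)(F)F)cc(C(F)(F)F)c4)c3)cc2-c2ccncc2)c1` gives -47% in this assay, a lower number, while compound 3 `COc1cc(Cl)cc(-c2nn(-c3cccc(NC(=O)Nc4ccc(Cl)c(Cl)c4)c3)cc2-c2ccncc2)c1` gives 2%, and the step of a number 31 percentage points higher from compound 1 to compound 3 (beyond the scatter) was made by chloro in place of trifluoromethyl on an aromatic carbon.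

Compound 4 `COc1cc(Cl)cc(-c2nn(-c3cccc(NC(=O)Nc4cccc(C(F)(F)F)c4)c3)cc2-c2ccncc2)c1` is not yet measured. It differs from compound 1 by hydrogen in place of chloro on an aromatic carbon. For the measured compounds named here, no measured step is of the same kind; the only step in this set, from compound 1 to compound 3, is large, and it replaced the trifluoromethyl rather than the chloro. That step suggests the read-out is sensitive to changes on this aryl ring, so a move toward a higher number of moderate size is expected, but with wide uncertainty. Compound 4 is therefore estimated at -15%, within -40% to 10%, an expected step of a number 14 percentage points higher from compound 1 to compound 4 (beyond the scatter).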

Compound 4, a percentage reported as activity, at one concentration (the size of the read-out at that concentration, not a potency): -22%
For compound 4 the middle estimate is 7 percentage points above the measured one; the range from low to high includes it.
By their numbers in this assay, from the lowest: compound 2; then compounds 1 and 4 (each within the scatter of the next); then compound 3.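

With the change from 4-chloro-3-(trifluoromethyl)phenyl to 3-(trifluoromethyl)phenyl, this assay shows a number 7 percentage points higher from compound 1 to compound 4 (within the scatter), so the chloro ortho to the trifluoromethyl group can give way to hydrogen without a change beyond the usual scatter. Other changes on this aryl ring do move the read-out beyond the scatter: 3-(trifluoromethyl)phenyl in place of 3,4-dichlorophenyl gives a number 24 percentage points lower from compound 3 to compound 4 (beyond the scatter), and hydrogen in place of a trifluoromethyl group gives a number 25 percentage points higher from compound 2 to compound 4 (beyond the scatter). No available measurement explains why these steps differ in size.

From the compounds shown here alone, it remains open whether an amine or a carboxylic acid in place of the chloro would shift the number beyond the scatter. Also open, going by these compounds, is how a methoxy group in place of the trifluoromethyl of compound 4 would read.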